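Swapping a Flexible Amine Chain for a Small Ring

This account rests on a few compounds, and the source may have more. Where it says the series, first, only, none or still open, it means among the compounds named here.

Of the compounds shown here, three sharing one core have been measured in a functional assay on CHO cells for antagonist activity at C-C chemokine receptor type 4 (Homo sapiens), read by radioligand binding and GTPgammaS binding; on this read-out higher numbers stand for weaker inhibition and lower numbers for stronger inhibition. Compound 1 `COc1cc2c(cc1NS(=O)(=O)c1cccc(Cl)c1Cl)[nH]c(=O)n2C(C)C` carries an isopropyl group on an aromatic nitrogen and gives 1000 nM. Compound 2 `COc1cc2c(cc1NS(=O)(=O)c1cccc(Cl)c1Cl)[nH]c(=O)n2C1COC1` carries an oxetan-3-yl group at that nitrogen and gives 112 nM. Compound 3 `COc1cc2c(cc1NS(=O)(=O)c1cccc(Cl)c1Cl)[nH]c(=O)n2CCN(C)C`, with a 2-(dimethylamino)ethyl group there, gives 2000 nM, the highest number of the three; its gap to compound 1 is within the scatter, whereas an 18-fold higher number from compound 2 to compound 3 (1.25 log units; beyond the scatter) is a clear step.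

Compound 4 `COc1cc2c(cc1NS(=O)(=O)c1cccc(Cl)c1Cl)[nH]c(=O)n2C1CN(C(C)=O)C1` differs from compound 3 in one place: 1-acetylazetidin-3-yl in place of 2-(dimethylamino)ethyl on an aromatic nitrogen. Within the data shown here, the measured step bearing most directly on this is the one from compound 2 to compound 3, where a chain replaced a four-membered ring and the number rose sharply; an 8.9-fold lower number from compound 1 to compound 2 (0.95 log units; beyond the scatter) likewise favoured the four-membered ring. Compound 4 is expected to move the number back down, roughly a 9.1-fold lower number from compound 3 to compound 4 (0.96 log units; beyond the scatter), because an 18-fold higher number from compound 2 to compound 3 (1.25 log units; beyond the scatter) shows how much that chain had cost. Compound 4 is therefore estimated at 220 nM, within a range from 60 nM to 800 nM.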

Compound 4, half-maximal inhibitory concentration: 200 nM
Compound 4: the middle estimate sits 1.1-fold (0.04 log units) above what was measured; measured number inside the range.
By their numbers in this assay, from the lowest: compounds 2 and 4 (each within the scatter of the next); then compounds 1 and 3 (each within the scatter of the next).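

In this assay, a second four-membered ring also beats the flexible chain at this ring nitrogen, with a 10-fold lower number from compound 3 to compound 4 (1.00 log units; beyond the scatter), so the low number is not unique to oxetan-3-yl. Exchanging that ring for the larger 1-acetylazetidin-3-yl brings no clear change, since a 1.8-fold higher number from compound 2 to compound 4 (0.25 log units; within the scatter) stays inside the usual variation between repeats. Against the open isopropyl group, the new ring also gives a clear gain, with a 5.0-fold lower number from compound 1 to compound 4 (0.70 log units; beyond the scatter), matching the direction already seen with compound 2.

Nothing available gives a reason for these differences. The compounds shown leave open whether the ring needs its hetero atom at all, which a plain cyclobutyl group would test, and whether the acetyl group matters, which an azetidine with a free amine would test.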